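A Ring-Closed Amine Variant of Compound 1

This account rests on a few compounds, and the source may have more. Where it says the series, first, only, none or still open, it means among the compounds named here.

Two compounds have so far been measured in a functional assay on Umbilical vein for antagonist activity at B1 bradykinin receptor (Homo sapiens), using Schild analysis, with a stated time of 30 min; on this read-out higher numbers stand for higher potency (the scale is a negative logarithm) and lower numbers for lower potency:

Compound 1, `CCN(CC)CCN1CCN(C(=O)COCCN(C)S(=O)(=O)c2c(C)cc(OC)cc2C)CC1`: 7.8
Compound 2, `Cc1c(Cl)ccc(S(=O)(=O)N(C)CCOCC(=O)N(C)Cc2ccc(C3=NCCN3)cc2)c1Cl`: 9.1

Compound 1 stands at the lower of these two numbers; compound 2 lies higher by a margin beyond the usual scatter. The two differ in many places at once, so their gap says nothing about any single change. Compound 3, `CCN1CCC(N2CCN(C(=O)COCCN(C)S(=O)(=O)c3c(C)cc(OC)cc3C)CC2)CC1`, has not yet been measured in this assay. It departs from compound 1 in one place: 1-ethylpiperidin-4-yl in place of 2-(diethylamino)ethyl on an amine nitrogen in a ring. The amine nitrogen of the entering group thus sits in a ring rather than in an open chain. Among the compounds with values here, no measured pair shows what such an exchange does here, so the expectation rests on compound 1 alone. The step from compound 1 to compound 3 in this assay is expected to be small, no change at the digits printed from compound 1 to compound 3 (within the scatter), with no direction beyond the scatter. Compound 3 is therefore estimated at 7.8, between 7.2 and 8.4.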

Compound 3, negative logarithm of the antagonist equilibrium constant: 8.8
Estimate against measurement, compound 3: 1.00 log units below; the measured number lies above the stated range.
By their numbers in this assay, from the lowest: compound 1; then compounds 3 and 2 (each within the scatter of the next).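

Exchanging 2-(diethylamino)ethyl for 1-ethylpiperidin-4-yl on the amine nitrogen in a ring gives a number 1.00 log units higher from compound 1 to compound 3 (beyond the scatter) in this assay, the first change in a single place among these compounds. It shows that this position responds to the form of the group it carries: the hydrogen-bond donor and acceptor counts stay the same, yet the open chain and the six-membered non-aromatic ring give clearly different numbers. No measurement on hand gives a reason for this rise.

The ring and the extra carbon enter together, so the compounds leave open which of the two accounts for the step. They also leave open whether 1-methylpiperidin-4-yl, or an open-chain amine with the same number of carbons, would keep the higher number.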